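This account rests on a few compounds, and the source may have more. Where it says the series, first, only, none or still open, it means among the compounds named here.

The study measured three compounds in a functional assay on HeLa cells (Homo sapiens) for cytotoxicity, read by neutral red uptake, with a stated time of 3 days; on this read-out lower numbers stand for stronger inhibition and higher numbers for weaker inhibition. Compound 1 `Nc1ccc(-c2cc(=O)c3c(N)c(F)cc(F)c3o2)cc1F` reaches only a limit there, > 100000 nM. Compound 2 `CCCCc1c(F)c(N)c2c(=O)cc(-c3ccc(N)c(F)c3)oc2c1F` likewise stops at the limit, > 100000 nM. Compound 3 `C[S+]([O-])c1c(F)c(N)c2c(=O)cc(-c3ccc(N)c(F)c3)oc2c1F` also ends at the limit, > 100000 nM. Because all three values sit at the limit of > 100000 nM in this assay, at which 3 of the 3 values shown sit, none of the steps between them can be read: a step that the two limits leave unreadable from compound 1 to compound 2, a step that the two limits leave unreadable from compound 1 to compound 3 and a step that the two limits leave unreadable from compound 2 to compound 3. Compound 3 therefore stands where the other two stand, at the limit of this assay, without a number of its own. Compound 4 `Nc1ccc(-c2cc(=O)c3c(N)c(F)c(O)c(F)c3o2)cc1F` differs from compound 3 by one oxygen atom in place of a group of 3 heavy atoms (1 carbon, 1 oxygen, 1 sulfur; no ring), on an aromatic carbon. Going by the values given here, the measured steps that bear on this change, the butyl entering and the group of 3 heavy atoms entering or replacing it, were all unreadable, so no measured step points in either direction in this assay. Compound 4 is accordingly expected to remain at the limit, and the step of a number no higher from compound 3 to compound 4 (the limit leaves the size open) is estimated to be no real change. The estimate for compound 4 is 100000 nM, within a range from 30000 nM to 300000 nM, most probably reported again only as a limit.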

Compound 4, half-maximal inhibitory concentration: > 100000 nM
Compound 4 gave a limit, no number; the forecaster's own chance of this, stated with the estimate: 80%; the middle value lies on the limit itself.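

The steps from compound 4 to compound 1, compound 2 and compound 3 in this assay cannot be read, because every value is only a limit: the limit of > 100000 nM in this assay, at which 4 of the 4 values shown sit. The compounds shown leave open whether hydrogen, butyl, hydroxy or the group of 3 heavy atoms on that aromatic carbon changes cytotoxicity at all.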